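Phenyl for Ethyl on a Ring Nitrogen: Cytotoxicity Outlook

The compounds below may be only part of what the source reports. "The series", "measured", "known", "first", "only" and "open" are said of these compounds alone.

Compound 1, `Nc1nc(Cl)c(-c2nc3ccc(F)cc3s2)c(N[C@@H]2C[C@H](CO)[C@@H](O)[C@H]2O)n1`: > 25000 nM
Compound 2, `CCNc1nc(C)c(-c2nc3ccccc3s2)c(N[C@@H]2C[C@H](CO)[C@@H](O)[C@H]2O)n1`: 12000 nM

In an ADME assay on cells (Homo sapiens) for cytotoxicity, read by polymerase chain reaction, with a stated time of 3 days (on this read-out lower numbers stand for higher toxicity in this test and higher numbers for lower toxicity in this test), compound 1 gives > 25000 nM, a limit of the test rather than a number. Compound 1 therefore sits at the limit of > 25000 nM in this assay, at which 1 of the 2 values shown sits. In this assay, among the measured compounds shown here, compound 2 gives 12000 nM, the only number recorded here. Compound 3, `Cc1nc(Nc2ccccc2)nc(N[C@@H]2C[C@H](CO)[C@@H](O)[C@H]2O)c1-c1nc2ccccc2s1`, has not yet been measured in this assay; it differs from compound 2 by phenyl in place of ethyl on a nitrogen on an aromatic ring. For the measured compounds named here, no measured pair isolates this change, so the expected step is no change at the digits printed from compound 2 to compound 3 (within the scatter), within the scatter. Compound 3 is estimated at 12000 nM, in a range from 4000 nM to 30000 nM.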

Compound 3, half-maximal cytotoxic concentration: > 25000 nM
Compound 3: only a limit was reported; the forecaster's own chance of this, stated with the estimate: 30%; at least 2.0-fold (0.31 log units) between middle value and limit.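

In this assay, among the compounds shown here, phenyl in place of ethyl on a nitrogen on an aromatic ring gives an at least 2.0-fold higher number from compound 2 to compound 3 (0.31 log units; beyond the scatter), the first step that can be read at this position. Compound 3 gives > 25000 nM, which is a limit of the test and not a number. The limit now holds most of the values shown: the limit of > 25000 nM in this assay, at which 2 of the 3 values shown sit.

Going by these compounds, the full size of the step remains open, since the limit hides how far the true value of compound 3 lies. Also open, on these data alone, is whether a benzyl group or a longer chain such as butyl on this nitrogen would give the same result.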